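The compounds below may be only part of what the source reports. "The series", "measured", "known", "first", "only" and "open" are said of these compounds alone.

In an assay on HeLa cells for inhibition of Indoleamine 2,3-dioxygenase 1 (Homo sapiens) (on this read-out higher numbers stand for weaker inhibition and lower numbers for stronger inhibition), compound 1 `O=C(Nc1ccc(Cl)cc1)C1(c2ccc3c(c2)CCN3c2ccccn2)CCC1` gives 1.6 nM, and compound 2 `Cc1nccc(N2CCc3cc(C4(C(=O)Nc5ccc(F)cc5)CCC4)ccc32)n1` gives 5.2 nM, the higher of the two numbers, a gap beyond the scatter. Compound 3 `O=C(Nc1ccc(F)cc1)C1(c2ccc3c(c2)CCN3c2ccccn2)CCC1` differs from compound 2 by pyridin-2-yl in place of 2-methylpyrimidin-4-yl on a nitrogen on an aromatic ring in a ring. Since compound 1 carries the same pyridin-2-yl and reaches 1.6 nM, the change from compound 2 to compound 3 is expected to bring a modest step downward, a 2.1-fold lower number from compound 2 to compound 3 (0.32 log units; beyond the scatter), though it may also stay within the scatter. Compound 3 is therefore estimated at 2.5 nM in this assay, with a likely range from 1 nM to 7 nM.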

Compound 3, half-maximal inhibitory concentration: 3.1 nM
The estimate for compound 3 lay 1.2-fold (0.09 log units) below the measured number, and the stated range covers the measured number.
By their numbers in this assay, from the lowest: compounds 1, 3 and 2 (each within the scatter of the next, the first and the last beyond it).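

On the nitrogen, pyridin-2-yl in place of 2-methylpyrimidin-4-yl gives a 1.7-fold lower number from compound 2 to compound 3 (0.22 log units; within the scatter) in this assay, so this assay does not separate the two rings at this position. Fluoro in place of chloro on an aromatic carbon gives a 1.9-fold higher number from compound 1 to compound 3 (0.29 log units; within the scatter) and is likewise not separated. Nothing available here accounts for either result. Still open, on these data alone, is whether a morpholine or a piperidine on this nitrogen would stay within the same range, and whether a nitrile or a methoxy group in place of the halogen would do so.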